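The compounds below may be only part of what the source reports. "The series", "measured", "known", "first", "only" and "open" are said of these compounds alone.

Measured so far in a physicochemical assay for lipophilicity, measured as octanol-water partition; a lower number here means a more polar compound, a higher number a more lipophilic compound:
compound 1, `COc1ccc2c(c1)[n+]([O-])c(C#N)c(-c1ccc(F)cc1)[n+]2[O-]`; compound 1 gives 1.97
compound 2, `Cc1ccc(-c2c(C#N)[n+]([O-])c3cc(Cl)ccc3[n+]2[O-])cc1`; compound 2 gives 2.6
compound 3, `Cc1ccc(-c2c(C#N)[n+]([O-])c3cc(C)ccc3[n+]2[O-])cc1`; compound 3 gives 2.33

Compound 1 holds the lowest of the three numbers; compound 3 sits nearest to it, beyond the scatter, and compound 2 sits furthest. Going by the values given here, the only measured step, a number 0.27 log units lower from compound 2 to compound 3 (within the scatter), concerns a different exchange and bears on the present change only loosely. Compound 4, `COc1ccc2c(c1)[n+]([O-])c(C#N)c(-c1ccc(C)cc1)[n+]2[O-]`, is not yet measured; it differs from compound 1 by methyl in place of fluoro on an aromatic carbon. Among the compounds with values here, no measured pair in this set shows that exchange. In this assay a modest rise from compound 1 to compound 4 is expected, somewhat beyond the scatter. Compound 4 is estimated at 2.35, with a range of 2.05 to 2.65. The step this estimate implies is a number 0.38 log units higher from compound 1 to compound 4 (beyond the scatter).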

Compound 4, partition coefficient: 1.83
The estimate for compound 4 lay 0.52 log units above the measured number; the whole stated range lies above it.
By their numbers in this assay, from the lowest: compounds 4 and 1 (each within the scatter of the next); then compounds 3 and 2 (each within the scatter of the next).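

In this assay the exchange of 4-fluorophenyl for 4-methylphenyl on the methoxy-bearing core gives a number 0.14 log units lower from compound 1 to compound 4 (within the scatter), so this position shows no resolved change for this pair. With 4-methylphenyl held constant, the substituent on the core does produce steps beyond the scatter, with a number 0.50 log units lower from compound 3 to compound 4 (beyond the scatter) and a number 0.77 log units lower from compound 2 to compound 4 (beyond the scatter). Nothing available explains either result.

As far as these compounds go, whether the same exchange stays within the scatter on the chloro or methyl cores remains open. Also open, from the compounds shown here alone, is how an amine or a carboxylic acid in place of fluoro would read in this assay.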